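A few compounds are considered here, and "the series" means these few. Any claim that something is new, unique, unknown or untested is made for them only; others in the source may bear on it.

Working notes on the series.

Compound 1 `CC(C)(C)[C@H]1CC[C@]2(CC1)N=C(c1cccc(C(F)(F)F)c1)C(=O)N2Cc1ccc(C(=O)NCCC(=O)O)cc1` is the reference point. In a functional assay on CHO cells for antagonist activity at Glucagon receptor (Homo sapiens), read by cAMP accumulation, with stated times of 30 min and 45 min (a higher number here means a weaker inhibitor, a lower number a stronger inhibitor), compound 1 gives 510 nM, the lowest of the three numbers recorded so far. Compound 2 `CC(C)[C@H](c1ccc(C(=O)NCc2nn[nH]n2)cc1)N1C(=O)C(c2cc(Cl)cc(Cl)c2)=N[C@]12CC[C@@H](C(C)(C)C)CC2` gives 2200 nM in this assay, and compound 3 `CC(C)(C)CC[C@H](c1ccc(C(=O)NCCS(=O)(=O)O)cc1)N1C(=O)C(c2cc(Cl)cc(Cl)c2)=N[C@]12CC[C@@H](C(C)(C)C)CC2` gives 8500 nM; both lie above compound 1 by more than the usual scatter, compound 3 by the wider margin. Neither compound 2 nor compound 3 differs from compound 1 in a single place, so no step can be read between them and compound 1; their numbers stand on their own.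

Compound 4 `CC(C)(C)[C@H]1CC[C@]2(CC1)N=C(c1ccc(Cl)cc1)C(=O)N2Cc1ccc(C(=O)NCCC(=O)O)cc1` has not been measured. It differs from compound 1 in one place: 4-chlorophenyl in place of 3-(trifluoromethyl)phenyl on a carbon with a double bond to nitrogen. Going by the values given here, no measured pair in the set isolates this change, so the size of the step is uncertain. For compound 4 a somewhat higher number than for compound 1 is expected, the step from compound 1 to compound 4 estimated at a 2.9-fold higher number from compound 1 to compound 4 (0.47 log units; beyond the scatter), with a fair chance that it stays within scatter. Compound 4 is expected to give about 1500 nM in this assay, in the range 400 nM to 6000 nM.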

Compound 4, half-maximal inhibitory concentration: 1400 nM
The estimate for compound 4 lay 1.1-fold (0.03 log units) above the measured number; measured number inside the range.
By their numbers in this assay, from the lowest: compound 1; then compounds 4 and 2 (each within the scatter of the next); then compound 3.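

In this assay, going by these compounds alone, 4-chlorophenyl in place of 3-(trifluoromethyl)phenyl on the carbon with a double bond to nitrogen gives a 2.7-fold higher number from compound 1 to compound 4 (0.44 log units; beyond the scatter), a modest step and the first reading that isolates a single place. With the rest of compound 1 held constant, including the chain bearing the carboxylic acid, the aryl group at this position is shown to affect the number, which compounds 2 and 3 could not show as they differ from compound 1 in more than one place. Nothing available accounts for the size or direction of this step.

The compounds shown do not separate the identity of the substituent from where it sits on the phenyl ring, as chloro and trifluoromethyl each appear here with a different ring number. Within the data shown here, also open are how a nitrile or a methoxy group on that phenyl ring, or a pyridine ring in its place, would read, and whether the step would carry over to a core with a different chain in place of the one in compound 1.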